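Compound 4: methylcarbamoyl replaces the hydroxycarbamoyl chain end

The compounds below may be only part of what the source reports. "The series", "measured", "known", "first", "only" and "open" are said of these compounds alone.

Measured in a functional assay on PLC-PRF-5 cells (Homo sapiens) for inhibition, read by MTT assay, with a stated time of 72 h (a higher number here means a weaker inhibitor, a lower number a stronger inhibitor), each value a limit:
- compound 1 `Nc1ncnc2c1c(-c1cnc3[nH]ccc3c1)nn2CCCCCC(=O)NO`: > 150000 nM
- compound 2 `Nc1nc2cc(-c3nn(CCCCCCCCCC(=O)NO)c4ncnc(N)c34)ccc2o1`: > 100000 nM
- compound 3 `Nc1ncnc2c1c(-c1cnc3[nH]ccc3c1)nn2CCCCCCC(=O)NO`: > 50000 nM

Compound 2 stands only at a limit (> 100000 nM), not at a number, and so do the other two compounds. In compound 4 `CNC(=O)CCCCCCCn1nc(-c2ccc3oc(N)nc3c2)c2c(N)ncnc21`, methylcarbamoyl takes the place of 2-(hydroxycarbamoyl)ethyl on a saturated chain carbon, seven bonds along the chain from an aromatic nitrogen (methylcarbamoyl in place of 2-(hydroxycarbamoyl)ethyl on a saturated chain carbon, seven bonds along the chain from an aromatic nitrogen). Going by the values given here, the one measured step, a step that the two limits leave unreadable from compound 1 to compound 3, has no readable size, so no step beyond the scatter is expected in this assay, and no direction can be given. The expected change is a number no higher from compound 2 to compound 4 (the limit leaves the size open). For compound 4 the estimated value is 100000 nM, with an expected range from 30000 nM to 300000 nM.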

Compound 4, half-maximal inhibitory concentration: 30500 nM
For compound 4 the middle estimate is 3.3-fold (0.52 log units) above the measured one; the range from low to high includes it.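

In this assay, going by these compounds alone, methylcarbamoyl in place of 2-(hydroxycarbamoyl)ethyl gives an at least 3.2-fold lower number from compound 2 to compound 4 (0.51 log units; beyond the scatter), the only readable step here, as the step among the earlier compounds cannot be read. Compound 4 is also the only compound shown that gives a number rather than a limit, so an inhibitory value can be read without the hydroxycarbamoyl end. Compound 2 stands only at a limit, so the full size of the step stays open: the limit of > 100000 nM in this assay, at which 1 of the 4 values shown sits.

The compounds shown leave open how much of the step belongs to the new chain end and how much to the shorter chain. They also leave open how a carboxylic acid or an amine at this place would read.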